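Triazole-linked piperidinones against prostate carcinoma cells

The compounds below may be only part of what the source reports. "The series", "measured", "known", "first", "only" and "open" are said of these compounds alone.

In a functional assay on PC-3 cells (Homo sapiens) for cytotoxicity, read by MTT assay, with a stated time of 24 h (a lower number here means a stronger inhibitor, a higher number a weaker inhibitor), the measured compounds stand as follows.
Compound 1, `COc1ccc(/C=C2\CN(C(=S)SCc3cn(Cc4ccc(F)cc4)nn3)C/C(=C\c3ccc(OC)cc3)C2=O)cc1`, gives 45600 nM.
Compound 2, `Cc1ccc(/C=C2\CN(Cc3cn(Cc4ccc(F)cc4)nn3)C/C(=C\c3ccc(C)cc3)C2=O)cc1`, gives 65600 nM.
Compound 3, `COc1ccc(/C=C2\CN(C(=S)SCc3cn(Cc4cccc(Cl)c4)nn3)C/C(=C\c3ccc(OC)cc3)C2=O)cc1`, reaches only a limit of this assay, > 80000 nM.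

One change recurs here: 3-chlorophenyl in place of 4-fluorophenyl on a saturated chain carbon bound to an aromatic nitrogen. It gave an at least 1.7-fold higher number from compound 1 to compound 3 (0.24 log units; that floor lies within the scatter), a floor set because compound 3 sits at the limit of > 80000 nM in this assay, at which 1 of the 3 values shown sits. The difference between the cores of compound 1 and compound 2 is not broken down here; their two values lie within the scatter of each other.

Compound 4, `Cc1ccc(/C=C2\CN(Cc3cn(Cc4cccc(Cl)c4)nn3)C/C(=C\c3ccc(C)cc3)C2=O)cc1`, carries the same change on the core of compound 2: 3-chlorophenyl in place of 4-fluorophenyl on a saturated chain carbon bound to an aromatic nitrogen. An equal step, a 1.7-fold higher number from compound 2 to compound 4 (0.22 log units; within the scatter), is expected, resting on an at least 1.7-fold higher number from compound 1 to compound 3 (0.24 log units; that floor lies within the scatter) in compound 1 and compound 3. Compound 4 is thus estimated at 110000 nM, between 55000 nM and 220000 nM.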

Compound 4, half-maximal inhibitory concentration: 29300 nM
Compound 4: the middle estimate sits 3.8-fold (0.57 log units) above what was measured; measured number below the stated range.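

On the core of compound 2, 3-chlorobenzyl in place of 4-fluorobenzyl gives a 2.2-fold lower number from compound 2 to compound 4 (0.35 log units; beyond the scatter) in this assay. Set beside the same change on the core of compound 1, this step shows that the change does not carry over unchanged from one core to the other: the same change on two cores in this assay, an at least 1.7-fold higher number (0.24 log units; that floor lies within the scatter) from compound 1 to compound 3 and a 2.2-fold lower number (0.35 log units; beyond the scatter) from compound 2 to compound 4, at least 3.9-fold (0.59 log units) apart, beyond the scatter of two such steps. Going by these compounds alone, with only two pairs, one of them resting on a limit of the assay, this does not show which part of the cores matters, nor how the change would behave on any further core.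

The two cores differ in more than one place, and the compounds shown do not separate those places. Going by these compounds, how a nitrile or a methoxy group on the benzyl ring would behave on either core also remains open.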